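Swapping a ring azido for hydroxy in compound 2

This account rests on a few compounds, and the source may have more. Where it says the series, first, only, none or still open, it means among the compounds named here.

Compound 1 `C=C(C)[C@@H]1CC=C(CN(OC)C2O[C@H](CO)[C@@H](N=[N+]=[N-])[C@H](O)[C@H]2O)CC1`: 22000 nM
Compound 2 `C=C(C)[C@@H]1CC=C(CN(OC)C2O[C@H](CN=[N+]=[N-])[C@@H](N=[N+]=[N-])[C@H](O)[C@H]2O)CC1`: 57000 nM
Compound 3 `C=C(C)[C@@H]1CC=C(CN(OC)C2O[C@H](CNC(=O)CCCCCCCCC)[C@@H](O)[C@H](O)[C@H]2O)CC1`: 30000 nM

All three compounds were tested in a functional assay on PC-3 cells (Homo sapiens) for cytotoxicity, read by resazurin assay, with a stated time of 48 h; a higher number here means a weaker inhibitor, a lower number a stronger inhibitor. Compound 2 cannot be told apart from compound 3, as their two numbers lie within the usual scatter. Its number is higher than that of compound 1, and that gap lies beyond the scatter.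

Compound 4 `C=C(C)[C@@H]1CC=C(CN(OC)C2O[C@H](CN=[N+]=[N-])[C@@H](O)[C@H](O)[C@H]2O)CC1` differs from compound 2 by hydroxy in place of azido on a saturated ring carbon. Compound 4 keeps the azidomethyl group.

Among the measured compounds shown here, no measured step changes this ring azido itself, so the evidence is indirect. The closest guide is a modest step, a 2.6-fold higher number from compound 1 to compound 2 (0.41 log units; beyond the scatter), where azido replaced hydroxy on a saturated chain carbon. The change to compound 4 is the same kind of exchange run the other way, at a different place. A modest move to a lower number in this assay is therefore expected, of about the same size, although a single step is a thin basis and the move may not clear the scatter. The expected step is a 2.4-fold lower number from compound 2 to compound 4 (0.38 log units; beyond the scatter).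

For compound 4 the estimated value is 24000 nM, with an expected range from 10000 nM to 55000 nM.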

Compound 4, half-maximal inhibitory concentration: 182000 nM
Compound 4: the middle estimate sits 7.6-fold (0.88 log units) below what was measured, outside the stated range (above it).
By their numbers in this assay, from the lowest: compounds 1, 3 and 2 (each within the scatter of the next, the first and the last beyond it); then compound 4.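

On the saturated ring carbon, hydroxy in place of azido cost activity rather than gaining it, with a 3.2-fold higher number from compound 2 to compound 4 (0.50 log units; beyond the scatter) in this assay, so at this position the azido is the better of the two groups. Set beside a 2.6-fold higher number from compound 1 to compound 2 (0.41 log units; beyond the scatter), where azido entered on a saturated chain carbon, this shows the number rising both when an azido enters at the chain and when one leaves the ring, so the outcome of this exchange depends on where it is made and does not carry over from one place to the other. Nothing among the data shown accounts for this difference between the two places.

The compounds shown leave open whether this ring carbon needs the azido itself or would serve as well with another group, such as an amine or an acetamide. They also leave open whether the ring azido has an effect of the same size when hydroxymethyl stands in place of the azidomethyl group, since the step here was read only with azidomethyl present.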